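Chain extension on the core of compound 3

The compounds below may be only part of what the source reports. "The series", "measured", "known", "first", "only" and "open" are said of these compounds alone.

Three compounds stand measured in an assay on isolated protein for inhibition of lysosomal alpha-glucosidase (Rattus norvegicus), read by colorimetric assay; a lower number here means a stronger inhibitor, a higher number a weaker inhibitor. Compound 3 `C[C@]1(CO)NC[C@@H](O)[C@@H]1O` gives 830 nM, the lowest number of the three. Its mirror image, compound 2 `C[C@@]1(CO)NC[C@H](O)[C@H]1O`, gives 2900 nM; the step of a 3.5-fold lower number from compound 2 to compound 3 (0.54 log units; beyond the scatter) rests on the fact that compounds 2 and 3 differ only in the configuration as drawn and on nothing else. Compound 1 `CCCCCCCCC[C@]1(CO)NC[C@@H](O)[C@@H]1O` gives 66000 nM, the highest number in the set.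

Compound 4 `CCCC[C@]1(CO)NC[C@@H](O)[C@@H]1O` has not yet been measured. It differs from compound 3 by propyl in place of hydrogen on a saturated chain carbon bound to a saturated ring carbon. Among the measured compounds shown here, the only measured step, the one from compound 2 to compound 3, concerns configuration alone and does not bear on a change of the chain. What does bear on it is the pair of values: compound 1 with 66000 nM against compound 3 with 830 nM shows that a much longer chain on that carbon goes with a far higher number. Compound 4 carries a group between the two in size, so a rise is expected, of a step of a 4.8-fold higher number from compound 3 to compound 4 (0.68 log units; beyond the scatter), well short of the gap to compound 1. Compound 4 is therefore expected to give about 4000 nM in this assay, within a range from 1200 nM to 15000 nM.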

Compound 4, half-maximal inhibitory concentration: 16000 nM
For compound 4 the middle estimate is 4.0-fold (0.60 log units) below the measured one; the whole stated range lies below it.
By their numbers in this assay, from the lowest: compound 3; then compound 2; then compound 4; then compound 1.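

In this assay, among the compounds shown here, the position tolerates chain growth far less well than the earlier compounds could show, since a short extension already gives a 19-fold higher number from compound 3 to compound 4 (1.29 log units; beyond the scatter). That step, read as methyl to butyl on the shared core, is larger than the one for the further extension of the chain, a 4.1-fold lower number from compound 1 to compound 4 (0.62 log units; beyond the scatter), so the smaller addition goes with the larger change. Across compound 3, compound 4 and compound 1, the number rises with each longer chain, and most of that rise is already reached with the butyl chain of compound 4, rather than building evenly up to the long chain of compound 1.

The compounds shown leave open how the number behaves for an ethyl chain, which would fall on the stretch where the rise is steepest, for hydrogen in place of the methyl of compound 3, and for a chain ending in a hydroxyl group, an amine or a carboxylic acid, which would separate the length of the chain from what it carries. The only explanatory fact on hand concerns configuration, so nothing available accounts for these steps along the chain.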